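Shortening the bromoalkyl chain in a chromone series

The source may report more compounds than this note shows. Statements on the series, on what has been measured and on what is new or still open speak of the compounds shown alone.

The two measured compounds share one core and differ only in the chain that hangs from an oxygen on an aromatic ring. Compound 1 `COc1ccc(-c2coc3cc(OCCCSC(=S)N4CCN(C)CC4)ccc3c2=O)cc1` carries a long chain ending in a six-membered ring and gives 24200 nM in a functional assay on ECa-109 cells for inhibition, with ECa-109 cell line (Homo sapiens) as the target, read by MTT assay, with a stated time of 48 h; a lower number here means a stronger inhibitor, a higher number a weaker inhibitor. Among the measured compounds shown here, compound 2 `COc1ccc(-c2coc3cc(OCCCCCBr)ccc3c2=O)cc1` carries a bromine-terminated chain instead, and in this assay compound 2 gives 59100 nM, the highest of the two numbers; the step of a 2.4-fold higher number from compound 1 to compound 2 (0.39 log units; beyond the scatter) is the only measured step, and it swaps the end group rather than the chain length.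

Compound 3 `COc1ccc(-c2coc3cc(OCCBr)ccc3c2=O)cc1` is the next compound. It differs from compound 2 by bromo in place of 3-bromopropyl on a saturated chain carbon, two bonds along the chain from an oxygen on an aromatic ring. For the measured compounds named here, no measured step addresses a change in chain length alone, so the data give no direction for this step. The expected step from compound 2 to compound 3 is therefore a 1.0-fold higher number from compound 2 to compound 3 (0.01 log units; within the scatter), nothing beyond the scatter. Compound 3 is estimated to give 60000 nM in this assay, with a range from 25000 nM to 145000 nM.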

Compound 3, half-maximal inhibitory concentration: 55100 nM
Beside the measured number, compound 3's estimate is 1.1-fold (0.04 log units) above it; low and high end bracket the measured number.
By their numbers in this assay, from the lowest: compound 1; then compounds 3 and 2 (each within the scatter of the next).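

Cutting the chain from 5-bromopentyl to 2-bromoethyl gives the first view of chain length with the bromine end kept, and in this assay the result is a 1.1-fold lower number from compound 2 to compound 3 (0.03 log units; within the scatter); across this pair, the shortening brings no readable change. Among the compounds shown here, the end group remains the only change here that lies beyond the scatter: alongside a 2.4-fold higher number from compound 1 to compound 2 (0.39 log units; beyond the scatter), the new comparison gives a 2.3-fold higher number from compound 1 to compound 3 (0.36 log units; beyond the scatter), so compound 1 keeps the lowest number against both bromine-ended compounds, whose chains differ in length. Nothing measured alongside these numbers accounts for either the flat step or the gap to compound 1.

Only the two chain ends of the bromine series are in view, so a 3-bromopropyl or 4-bromobutyl chain could still depart from the level shared by compound 2 and compound 3. As far as these compounds go, it also remains open how a simple amine or a carboxylic acid in place of the bromine would read, and whether the end group of compound 1 would keep its lower number on a shorter or longer chain.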